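The compounds below may be only part of what the source reports. "The series", "measured", "known", "first", "only" and "open" are said of these compounds alone.

Measured so far in an assay on isolated protein for displacement of a labelled ligand from metabotropic glutamate receptor 5 (Homo sapiens), with a stated time of 60 min, tested at 1 uM; a lower number here means less inhibition, a higher number more inhibition at the concentration tested (going by the name of the read-out):
compound 1 `CC1CCN(c2c(S(=O)(=O)c3cc(Cl)cc(Cl)c3)cnc3ccc(Cl)cc23)CC1`, 88%
compound 2 `Cc1ccc(S(=O)(=O)c2cnc3ccc(Cl)cc3c2N2CCC(C)CC2)cc1C`, 84%
compound 3 `CC1CCN(c2c(S(=O)(=O)c3cccc(Cl)c3)cnc3ccc(Cl)cc23)CC1`, 92%

Compound 1 stands second highest of the three numbers, yet none of the three is set apart: the step of a number 4 percentage points lower from compound 1 to compound 2 (within the scatter) and the step of a number 4 percentage points higher from compound 1 to compound 3 (within the scatter) both lie within the scatter, as does the step of a number 8 percentage points higher from compound 2 to compound 3 (within the scatter). The three measured compounds differ from one another only in the aryl group on the sulfonyl sulfur, and every such change left this assay essentially unmoved.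

Compound 4 `Cc1ccc2ncc(S(=O)(=O)c3cc(Cl)cc(Cl)c3)c(N3CCC(C)CC3)c2c1` is not yet measured. It differs from compound 1 in a single place: methyl in place of chloro on an aromatic carbon. For the measured compounds named here, no measured step touches this position, which sits on the fused carbocyclic ring of the shared core; the steps seen so far, all small, concern the sulfonyl aryl group only. Since those changes gave no step beyond the scatter, and compound 1 gives 88%, no step beyond the scatter is expected here either. Compound 4 is therefore estimated at 85% in this assay, with a range from 70% to 95%. For compound 4 this estimate means an expected a number 3 percentage points lower from compound 1 to compound 4 (within the scatter).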

Compound 4, a percentage reported as inhibition, at one concentration (the size of the read-out at that concentration, not a potency): 75%
Compound 4: middle estimate off by 10 percentage points, on the high side; the range from low to high includes it.
By their numbers in this assay, from the lowest: compounds 4, 2, 1 and 3 (each within the scatter of the next, the first and the last beyond it).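

The change of chloro to methyl gives a number 13 percentage points lower from compound 1 to compound 4 (beyond the scatter) in this assay and is the only single change shown that reaches beyond the scatter. This position on the shared core therefore responds to the exchange of one heavy atom for another, with no change in hydrogen-bond donors, acceptors or net charge, whereas the changes to the aryl group on the sulfonyl sulfur among compound 1, compound 2 and compound 3 all stayed within the scatter. Nothing available explains this step.

The compounds shown leave open how this position would respond to other groups, such as hydrogen, fluoro, methoxy or an amine. They also leave open whether the same exchange would give a step of similar size with 3-chlorophenyl or 3,4-dimethylphenyl on the sulfonyl sulfur.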